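Shortening the carbamate-bearing linker in the spiro series

A few compounds are considered here, and "the series" means these few. Any claim that something is new, unique, unknown or untested is made for them only; others in the source may bear on it.

Measured so far:
compound 1, `CC(C)(C)OC(=O)NC1CCCN(C(=O)CN2CN(c3ccccc3)C3(CCN(C(=O)c4ccc(C5CCCCC5)cc4)CC3)C2=O)C1`, 4400 nM
compound 2, `CC(C)(C)OC(=O)NCCCCCNC(=O)CN1CN(c2ccccc2)C2(CCN(C(=O)c3ccc(C(C)(C)C)cc3)CC2)C1=O`, 13700 nM

In an assay on HEK293 cells for displacement of a labelled ligand from NPC1-like intracellular cholesterol transporter 1 (Homo sapiens) (on this read-out lower numbers stand for stronger inhibition and higher numbers for weaker inhibition), compound 1 gives 4400 nM, while compound 2 gives 13700 nM. Compound 2 therefore holds the highest number of the two, and its nearest neighbour, compound 1, sits at a lower number by a gap beyond the usual scatter. The two compounds differ in more than one place, so only their two values can be compared.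

Compound 3, `CC(C)(C)OC(=O)NCCNC(=O)CN1CN(c2ccccc2)C2(CCN(C(=O)c3ccc(C(C)(C)C)cc3)CC2)C1=O`, has not yet been measured. It derives from compound 2 by the change ((tert-butoxycarbonyl)amino in place of 3-((tert-butoxycarbonyl)amino)propyl on a saturated chain carbon, two bonds along the chain from an amide-type nitrogen). Going by the values given here, no measured pair isolates this change, so the expectation rests on the two values alone, both of which are weak. The step of a 1.4-fold lower number from compound 2 to compound 3 (0.14 log units; within the scatter) is expected to be small and probably within the scatter. Compound 3 is estimated at 10000 nM, with a range from 3000 nM to 35000 nM.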

Compound 3, half-maximal inhibitory concentration: 10900 nM
Compound 3: middle estimate off by 1.1-fold (0.04 log units), on the low side, and the stated range covers the measured number.
By their numbers in this assay, from the lowest: compound 1; then compounds 3 and 2 (each within the scatter of the next).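

Going by these compounds alone, the step of a 1.3-fold lower number from compound 2 to compound 3 (0.10 log units; within the scatter) in this assay is the first read that isolates one place: (tert-butoxycarbonyl)amino in place of 3-((tert-butoxycarbonyl)amino)propyl on a saturated chain carbon, two bonds along the chain from an amide-type nitrogen. The terminal carbamate stays and only the chain is shortened, so over these two lengths the read-out does not separate the two linkers. Nothing available explains this result.

Still open, as far as these compounds go, is whether the flat response holds once the terminal tert-butyl carbamate is replaced, for example by a free primary amine or a carboxylic acid, or whether a chain longer than that of compound 2 behaves the same way. How the piperidine-linked carbamate of compound 1 would behave with the other acyl group also remains unresolved.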